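Phenyl in place of chlorofluorophenyl on a weak sulfone

The source may hold more compounds than are shown below. What is called first, only, known or untested is meant among the compounds shown, and "the series" means these compounds.

Among the measured compounds shown here, compound 2 `CC(O)(CS(=O)(=O)c1ccc(Cl)cc1)c1nc(-c2ccc(F)c(Cl)c2)no1` carries the only number in a functional assay on DU-145 cells (Homo sapiens) for cytotoxicity, read by MTT assay (a lower number here means a stronger inhibitor, a higher number a weaker inhibitor), where compound 2 gives 35500 nM. Compound 1 `CC(O)(CS(=O)(=O)c1ccc(Br)cc1)c1nc(-c2ccccc2)no1` reaches only a limit of the assay. In this assay compound 1 gives > 100000 nM, a limit and not a number, as the limit of > 100000 nM in this assay, at which 1 of the 2 values shown sits, records. Compound 3 `CC(O)(CS(=O)(=O)c1ccc(Cl)cc1)c1nc(-c2ccccc2)no1` differs from compound 2 by phenyl in place of 3-chloro-4-fluorophenyl on an aromatic carbon. For the measured compounds named here, no measured step covers this change; compound 1 also bears phenyl on the core, with a different halogen on the sulfone ring. Compound 3 is expected to weaken, by a 2.3-fold higher number from compound 2 to compound 3 (0.35 log units; beyond the scatter), with a fair chance of reporting only a limit. Compound 3 is estimated at 80000 nM, between 25000 nM and 250000 nM.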

Compound 3, half-maximal inhibitory concentration: > 100000 nM
Compound 3 gave a limit, no number (the forecaster's own chance of this, stated with the estimate: 45%); middle value at least 1.2-fold (0.09 log units) away from the limit.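

Replacing 3-chloro-4-fluorophenyl with phenyl at this position, with the rest of the molecule unchanged, gives in this assay an at least 2.8-fold higher number from compound 2 to compound 3 (0.44 log units; beyond the scatter). Going by these compounds, compound 3 reports a limit and not a number, so the full size of this step stays unknown: the limit of > 100000 nM in this assay, at which 2 of the 3 values shown sit. The step from compound 1 to compound 3, chloro in place of bromo, cannot be read.

Whether the chloro or the fluoro accounts for the loss stays open. So does the effect of an amine or a carboxylic acid on this phenyl.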